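From Thiophene to Phenylsulfonyl: Expecting a Weaker Inhibitor

The source may hold more compounds than are shown below. What is called first, only, known or untested is meant among the compounds shown, and "the series" means these compounds.

Compound 2 `CCOC(=O)c1cnc(-c2ccsc2)nc1NN1C(=O)C=C(C)C1=O` gives 100 nM in a functional assay on Jurkat cells for inhibition of nuclear factor NF-kappa-B complex (Homo sapiens) (on this read-out higher numbers stand for weaker inhibition and lower numbers for stronger inhibition), the lowest of the two numbers measured; its nearest neighbour, compound 1 `CCOC(=O)c1cnc(-c2csc(C)n2)nc1NN1C(=O)C=C(C)C1=O`, gives 8000 nM. Compound 3 `CCOC(=O)c1cnc(S(=O)(=O)c2ccccc2)nc1NN1C(=O)C=C(C)C1=O` differs from compound 2 by phenylsulfonyl in place of thiophen-3-yl on an aromatic carbon. For the measured compounds named here, the one measured step at this position, an 80-fold lower number from compound 1 to compound 2 (1.90 log units; beyond the scatter), shows that the group here shifts the number greatly, yet it covers no phenylsulfonyl, so the direction remains uncertain. Because compound 2 already stands at 100 nM, the lowest seen, the expected step is a rise, a 20-fold higher number from compound 2 to compound 3 (1.30 log units; beyond the scatter). Compound 3 is therefore estimated at 2000 nM, within a range of 200 nM to 20000 nM.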

Compound 3, half-maximal inhibitory concentration: 10000 nM
Beside the measured number, compound 3's estimate is 5.0-fold (0.70 log units) below it, and the stated range covers the measured number.
By their numbers in this assay, from the lowest: compound 2; then compounds 1 and 3 (each within the scatter of the next).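

In this assay, phenylsulfonyl in place of thiophen-3-yl gives a 100-fold higher number from compound 2 to compound 3 (2.00 log units; beyond the scatter) and so shows that a second, quite different group also loses the low number of compound 2 at this position. Set against the 2-methyl-1,3-thiazol-4-yl group, phenylsulfonyl gives a 1.3-fold higher number from compound 1 to compound 3 (0.10 log units; within the scatter) and so does not separate from it, leaving thiophen-3-yl as the only one of the three groups with a low number. No measurement available here accounts for this.

From the compounds shown here alone, it remains open whether a thiophen-2-yl, a plain phenyl or an amine on this carbon would keep the number of compound 2. Going by these compounds, it is also open whether the sulfonyl link or the phenyl ring carries the loss seen with compound 3.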